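Dropping the Chloro Group: What Compound 3 Might Show

The source may hold more compounds than are shown below. What is called first, only, known or untested is meant among the compounds shown, and "the series" means these compounds.

Measured compounds:
- compound 1 `CC(Sc1nnc(-c2ccncc2)s1)C(=O)Nc1ccccc1Cl`: > 50000 nM
- compound 2 `O=C(CCSc1nnc(-c2ccncc2)s1)Nc1ccc(Cl)cc1`: 7260 nM

Of the compounds shown here, two have been tested in an ADME assay on HepG2 cells (Homo sapiens) for cytotoxicity, with a stated time of 3 days; on this read-out lower numbers stand for higher toxicity in this test and higher numbers for lower toxicity in this test. In this assay compound 1 gives > 50000 nM, which is a limit of the assay and not a number. In this assay compound 2 gives 7260 nM. Within the data shown here, compound 1 therefore stands at the limit only, as the line the limit of > 50000 nM in this assay, at which 1 of the 2 values shown sits, records; no step between compound 1 and compound 2 is counted, since the two differ in more than one place, and all that can be said is what the two values show.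

Compound 3 `CC(Sc1nnc(-c2ccncc2)s1)C(=O)Nc1ccccc1` has not yet been measured in this assay. It differs from compound 1 by hydrogen in place of chloro on an aromatic carbon. Among the measured compounds shown here, with compound 1 sitting at the limit, no counted step is available to guide the expectation, and the change is a small one. The step from compound 1 to compound 3 is expected to be a step that the limit leaves unreadable from compound 1 to compound 3, that is, none beyond the scatter. Compound 3 is estimated at 60000 nM, within the range from 20000 nM to 200000 nM, with a fair chance that the assay again reports only a limit.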

Compound 3, half-maximal cytotoxic concentration: > 50000 nM
Compound 3 was reported as a limit (the forecaster's own chance of this, stated with the estimate: 60%); the middle value is on the limit's open side.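

In this assay compound 3 gives > 50000 nM as a limit of the assay and not a number. Among these compounds, compound 1 also stands at a limit, so no step from compound 1 to compound 3 can be read: the limit of > 50000 nM in this assay, at which 2 of the 3 values shown sit. The compounds shown leave open whether hydrogen in place of chloro on an aromatic carbon changes the read-out at all.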